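Adding fluorine to the central ring of compound 1

The source may hold more compounds than are shown below. What is called first, only, known or untested is meant among the compounds shown, and "the series" means these compounds.

Measured compounds:
- Compound 1, `CCC(c1ccc(-c2cscc2C)cc1)n1ccnc1`, in an assay for inhibition of steroid 17-alpha-hydroxylase/17,20 lyase (Homo sapiens), using NADPH, tested at 0.2 uM (a higher number here means a stronger effect of the compound at the concentration tested, a lower number a weaker effect), gives 27%
- Compound 2, `Cc1cscc1-c1ccc(Cn2ccnc2)cc1`, in this assay gives 0%
- Compound 3, `CCC(c1ccc(-c2ccsc2Cl)cc1)n1ccnc1`, in this assay gives 40%

Compound 1 stands second of the three: compound 3 lies above it by a number 13 percentage points higher from compound 1 to compound 3 (beyond the scatter), and compound 2 lies below it by a number 27 percentage points lower from compound 1 to compound 2 (beyond the scatter), both gaps beyond the usual scatter. Compound 4, `CCC(c1ccc(-c2cscc2C)cc1F)n1ccnc1`, differs from compound 1 in one place only: fluoro in place of hydrogen on an aromatic carbon.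

Neither measured step touches this ring. The step to compound 2 removes the ethyl on the saturated carbon, and the step to compound 3 swaps the thiophene group; both were modest yet beyond the scatter, but neither tells how a fluoro on the central ring behaves. Among the measured compounds shown here, no measured pair bears directly on the change, so no step beyond the scatter is expected in this assay from compound 1 to compound 4, that is, about a number 3 percentage points higher from compound 1 to compound 4 (within the scatter).

Compound 4 is therefore estimated at 30%, within a range from 10% to 55%.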

Compound 4, a percentage reported as inhibition, at one concentration (the size of the read-out at that concentration, not a potency): 41%
The estimate for compound 4 lay 11 percentage points below the measured number, within the range that was stated.
By their numbers in this assay, from the lowest: compound 2; then compound 1; then compounds 3 and 4 (each within the scatter of the next).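

A single fluoro on an aromatic carbon of the six-membered aromatic ring of carbon only, ortho to a group of 8 heavy atoms and meta to the 4-methylthiophen-3-yl group, gives a number 14 percentage points higher from compound 1 to compound 4 (beyond the scatter) in this assay. Among the compounds shown here, this place on the shared core therefore responds to a change of just one heavy atom, which the earlier steps, made at the saturated chain carbon and at the thiophene group, could not show. No evidence here explains why the number rises.

As far as these compounds go, whether a methoxy group or an amine on this same aromatic carbon would also raise the number remains open. From the compounds shown here alone, it is also open whether the fluoro and the 2-chlorothiophen-3-yl group of compound 3 would add up when placed together in one compound.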